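This account rests on a few compounds, and the source may have more. Where it says the series, first, only, none or still open, it means among the compounds named here.

Compound 1 `COc1ccc(Cl)cc1S(=O)(=O)Nc1cncc(C(=O)Nc2ccccc2)c1`: 310 nM
Compound 2 `COc1ccc(C(N)=O)cc1S(=O)(=O)Nc1cccnc1`: 1490 nM

Of the compounds shown here, two have been measured in an assay on isolated protein for inhibition of alkaline phosphatase, tissue-nonspecific isozyme (Homo sapiens); a lower number here means a stronger inhibitor, a higher number a weaker inhibitor. For the measured compounds named here, compound 1 stands at the lower of the two numbers with 310 nM, and the only other measured compound, compound 2, lies at 1490 nM, a gap beyond the usual scatter of this assay; the two structures differ in several places at once, so no single change can be read from that gap.

The next compound, compound 3 `COc1ccc(Cl)cc1S(=O)(=O)Nc1cncc(C(=O)O)c1`, differs from compound 1 in one place: hydroxy in place of anilino on a carbonyl carbon. In plain terms, the phenylcarbamoyl group becomes a carboxy group, so a whole aromatic ring leaves and a single oxygen arrives. Going by the values given here, nothing among the measured compounds tests this change directly, so the expectation rests on the size of what is removed. Losing a ring of that size from a molecule of this kind is expected to cost potency, and the step from compound 1 to compound 3 is estimated at a 4.8-fold higher number from compound 1 to compound 3 (0.68 log units; beyond the scatter), a weakening beyond the scatter. Compound 3 is therefore expected to reach about 1500 nM in this assay, within a range from 400 nM to 6000 nM.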

Compound 3, half-maximal inhibitory concentration: 134 nM
Estimate against measurement, compound 3: 11-fold (1.05 log units) above, outside the stated range (below it).
By their numbers in this assay, from the lowest: compound 3; then compound 1; then compound 2.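

Replacing the phenylcarbamoyl group of compound 1 with a carboxy group gives a 2.3-fold lower number from compound 1 to compound 3 (0.36 log units; beyond the scatter) in this assay, so this position does not depend on the anilino part for activity in this pair. The six-membered aromatic ring can leave altogether, with a single hydroxy in its place on the carbonyl carbon, and the smaller compound carries the lower number; compounds 1 and 2 alone could not show this, as they differ in several places at once. No measurement shown here explains why this replacement lowers the number.

For the compounds shown here, still open is whether the hydroxy itself matters or whether removing the anilino part is what counts, as this pair changes both together and is the only comparison at this position. A methyl ester or a small methylamide on the same carbonyl carbon would help to separate these two readings, and a longer chain on the amide nitrogen would show how much size this position accepts between the hydroxy and the anilino extremes.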